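Hydroxamic acids on cisplatin-resistant ovarian cells: a cyclohexyl-to-tert-butyl swap

This account rests on a few compounds, and the source may have more. Where it says the series, first, only, none or still open, it means among the compounds named here.

Measured compounds:
compound 1, `CN(C)c1ccc(C(=O)N(CCCCCC(=O)NO)CC(=O)NC2CCCCC2)cc1`: 3310 nM
compound 2, `CC(C)(C(=O)NC1CCCCC1)N(CCCCCC(=O)NO)C(=O)c1ccccc1`: 281000 nM
compound 3, `CC(C)(C)NC(=O)C(C)(C)N(CCCCCC(=O)NO)C(=O)c1ccccc1`: 579000 nM

The three measured compounds were tested in a functional assay on A2780cisR cells (Homo sapiens) for cytotoxicity, read by MTT assay, with a stated time of 72 h; a higher number here means a weaker inhibitor, a lower number a stronger inhibitor. Compound 1 gives 3310 nM in this assay, the lowest of the three numbers; compound 2 gives 281000 nM and compound 3 gives 579000 nM, both far above it. The difference between the core of compound 1 and the core of compound 2 is not broken down here.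

Within the second core, one change is measured: tert-butyl in place of cyclohexyl on an amide-type nitrogen. This gives a 2.1-fold higher number from compound 2 to compound 3 (0.31 log units; beyond the scatter), a modest loss that nonetheless lies beyond the scatter.

The unmeasured compound 4, `CN(C)c1ccc(C(=O)N(CCCCCC(=O)NO)CC(=O)NC(C)(C)C)cc1`, carries the same change on the core of compound 1: tert-butyl in place of cyclohexyl on an amide-type nitrogen. The place of the change is described in the same words for both pairs, so the change is the same, only the surrounding core differs. Going by the values given here, the only guide to its size is the single measured instance, a 2.1-fold higher number from compound 2 to compound 3 (0.31 log units; beyond the scatter), on a core that is not broken down against that of compound 1.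

On that basis compound 4 is expected to show a step of a 2.1-fold higher number from compound 1 to compound 4 (0.33 log units; beyond the scatter) in this assay, similar in size to the measured one because of a 2.1-fold higher number from compound 2 to compound 3 (0.31 log units; beyond the scatter). Compound 4 is estimated at 7000 nM, with a range from 2800 nM to 20000 nM.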

Compound 4, half-maximal inhibitory concentration: 5180 nM
For compound 4 the middle estimate is 1.4-fold (0.13 log units) above the measured one, within the range that was stated.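

In this assay the new step is a 1.6-fold higher number from compound 1 to compound 4 (0.19 log units; within the scatter) and gives no ground for ranking compound 1 and compound 4 against each other. Set beside the measured step on the other core, tert-butyl in place of cyclohexyl on an amide-type nitrogen reads alike on both cores: the same change on two cores in this assay, a 2.1-fold higher number (0.31 log units; beyond the scatter) from compound 2 to compound 3 and a 1.6-fold higher number (0.19 log units; within the scatter) from compound 1 to compound 4, 1.3-fold (0.12 log units) apart, within the scatter of two such steps. This shows that the change carried from one core to the other in this series without a detectable difference in step size, but it rests on one pair per core, so it sets no rule for any further core and gives no explanation for the agreement.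

The compounds shown leave open how other groups on the same amide-type nitrogen, such as isopropyl or benzyl, would compare with cyclohexyl and tert-butyl on either core. They also leave open whether the agreement would survive a shorter or longer chain leading to the hydroxamic acid, and which of the features separating the core of compound 1 from the core of compound 2 goes with the large gap between their printed values.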